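Pyrimidin-2-yl in place of oxan-4-yl on an aromatic nitrogen

The source may hold more compounds than are shown below. What is called first, only, known or untested is meant among the compounds shown, and "the series" means these compounds.

Compound 1 `CCCn1nc(C(=O)N[C@H]2COc3ccccc3N(C)C2=S)nc1Cc1ccccc1` gives 288 nM
Compound 2 `CCCCCn1nc(C(=O)N[C@H]2COc3ccccc3N(C)C2=S)nc1Cc1ccccc1` gives 805 nM
Compound 3 `CN1C(=S)[C@@H](NC(=O)c2nc(Cc3ccccc3)n(C3CCOCC3)n2)COc2ccccc21` gives 2260 nM

In a functional assay on HT-29 cells (Homo sapiens) for inhibition, read by luminescence and CellTiter-Glo, with a stated time of 24 h (on this read-out lower numbers stand for an effect already at smaller amounts and higher numbers for an effect only at larger amounts of compound), compound 3 stands highest of the three at 2260 nM. Compound 4 `CN1C(=S)[C@@H](NC(=O)c2nc(Cc3ccccc3)n(-c3ncccn3)n2)COc2ccccc21` carries pyrimidin-2-yl in place of oxan-4-yl on an aromatic nitrogen. Among the compounds with values here, three measured steps bear on this substituent: a 7.8-fold higher number from compound 1 to compound 3 (0.89 log units; beyond the scatter), a 2.8-fold higher number from compound 2 to compound 3 (0.45 log units; beyond the scatter) and a 2.8-fold higher number from compound 1 to compound 2 (0.45 log units; beyond the scatter). All are modest, and none brings in an aromatic ring at this place, so the direction is poorly supported. With compound 3 at the top of the measured span, a modest move toward lower numbers is expected in this assay. The estimated step is a 2.3-fold lower number from compound 3 to compound 4 (0.35 log units; beyond the scatter). The estimate for compound 4 is 1000 nM, with an expected range from 220 nM to 4500 nM.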

Compound 4, half-maximal effective concentration: 3970 nM
For compound 4 the middle estimate is 4.0-fold (0.60 log units) below the measured one; the range from low to high includes it.
By their numbers in this assay, from the lowest: compound 1; then compound 2; then compounds 3 and 4 (each within the scatter of the next).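

In this assay an aromatic ring on this nitrogen can now be compared with a saturated ring: pyrimidin-2-yl in place of oxan-4-yl gives a 1.8-fold higher number from compound 3 to compound 4 (0.24 log units; within the scatter) and so does not separate the two rings. Against the chains, a 4.9-fold higher number from compound 2 to compound 4 (0.69 log units; beyond the scatter) for pentyl and a 14-fold higher number from compound 1 to compound 4 (1.14 log units; beyond the scatter) for propyl place both ring compounds at higher numbers than either chain, with the propyl gap the larger. No evidence on the cause of these differences is at hand.

Compound 1 at 288 nM leaves open whether ethyl on this nitrogen would give a lower number. Also open, going by these compounds, is how a ring carrying an amine at this place would compare.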